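Benzoyl for Benzyl on the Ring Nitrogen

The source may hold more compounds than are shown below. What is called first, only, known or untested is meant among the compounds shown, and "the series" means these compounds.

Measured compounds:
compound 1, `Fc1ccc(C(SCCNC2CCN(Cc3ccccc3)CC2)c2ccc(F)cc2)cc1`, 3.81 nM
compound 2, `Fc1ccc(CN2CCC(NCCSC(c3ccc(F)cc3)c3ccc(F)cc3)CC2)cc1`, 13.3 nM
compound 3, `Fc1ccc(C(SCCNC2CCN(Cc3ccc(C(F)(F)F)cc3)CC2)c2ccc(F)cc2)cc1`, 186 nM

In an assay on membranes from Cortex for displacement of a labelled ligand from Sigma non-opioid intracellular receptor 1 (Cavia porcellus), read by scintillation counting, with a stated time of 120 min (on this read-out lower numbers stand for stronger inhibition and higher numbers for weaker inhibition), compound 1 gives the lowest number of the three. Compound 2 sits nearest, with a 3.5-fold higher number from compound 1 to compound 2 (0.54 log units; beyond the scatter); compound 3 lies furthest, with a 49-fold higher number from compound 1 to compound 3 (1.69 log units; beyond the scatter), and between them a 14-fold higher number from compound 2 to compound 3 (1.15 log units; beyond the scatter). Every change made so far therefore weakens binding, and the larger the added group, the larger the loss.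

Compound 4, `O=C(c1ccccc1)N1CCC(NCCSC(c2ccc(F)cc2)c2ccc(F)cc2)CC1`, differs from compound 1 by benzoyl in place of benzyl on an amine nitrogen in a ring. Within the data shown here, none of the measured steps changes this nitrogen; all three alter the aromatic ring of the benzyl group. They show only that this region of the core of compound 1 does not tolerate additions well. Among the measured compounds shown here, with no direct precedent, the account expects a loss beyond the scatter for compound 4, probably of modest to large size, as a 16-fold higher number from compound 1 to compound 4 (1.20 log units; beyond the scatter). The estimate for compound 4 in this assay is 60 nM, within a range of 10 nM to 400 nM.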

Compound 4, inhibition constant: 2.03 nM
Beside the measured number, compound 4's estimate is 30-fold (1.47 log units) above it, and the stated range ends above it.
By their numbers in this assay, from the lowest: compounds 4 and 1 (each within the scatter of the next); then compound 2; then compound 3.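

In this assay, among these compounds, the first change at the amine nitrogen in a ring shows no loss: a 1.9-fold lower number from compound 1 to compound 4 (0.27 log units; within the scatter) shows that benzoyl, which brings a carbonyl and a hydrogen-bond acceptor, can take the place of benzyl without a difference beyond the scatter. The earlier steps shown here had altered only the aromatic ring of the benzyl group, so they had not tested this nitrogen substituent itself. Compound 4, with an unsubstituted benzoyl group, differs beyond the scatter from both substituted benzyl compounds, at a 6.6-fold lower number from compound 2 to compound 4 (0.82 log units; beyond the scatter) and at a 92-fold lower number from compound 3 to compound 4 (1.96 log units; beyond the scatter), and nothing available accounts for this tolerance.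

As far as these compounds go, whether fluoro or trifluoromethyl on the aromatic ring of the benzoyl group would cost as much as on the benzyl group remains open. So does the effect of replacing benzoyl with an acetyl group or a longer chain such as phenylacetyl.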